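The source may report more compounds than this note shows. Statements on the series, on what has been measured and on what is new or still open speak of the compounds shown alone.

In a functional assay on MDA-MB-468 cells (Homo sapiens) for inhibition, read by MTT assay (on this read-out lower numbers stand for stronger inhibition of growth and higher numbers for weaker inhibition of growth), three amides on a shared core have been measured, and compound 3 `CC1=C(/C=C/C(C)=C/C=C/C(C)=C\C(=O)NCc2ccccc2)C(C)(C)CCC1n1ccnc1` stands highest at 7240 nM, which makes it the weakest growth inhibitor of the three. Compound 2 `CC1=C(/C=C/C(C)=C/C=C/C(C)=C\C(=O)NCc2cccc(F)c2)C(C)(C)CCC1n1ccnc1` gives 3090 nM and compound 1 `CC1=C(/C=C/C(C)=C/C=C/C(C)=C\C(=O)Nc2ccccc2)C(C)(C)CCC1n1ccnc1` gives 2540 nM, and these two cannot be told apart (a 1.2-fold higher number from compound 1 to compound 2 (0.09 log units; within the scatter)).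

Compound 4 `CC1=C(/C=C/C(C)=C/C=C/C(C)=C\C(=O)NCc2ccc(F)cc2)C(C)(C)CCC1n1ccnc1` changes compound 3 in one place, with fluoro in place of hydrogen on an aromatic carbon, para to a large group (fluoro in place of hydrogen on an aromatic carbon). Benzyl thus becomes 4-fluorobenzyl.

The most relevant evidence is the pair that differs by a single fluoro on this same ring, although at another carbon (a 2.3-fold higher number from compound 2 to compound 3 (0.37 log units; beyond the scatter)). Read in reverse, that step shows a fluoro lowering the number modestly. The step from phenyl to benzyl (a 2.9-fold higher number from compound 1 to compound 3 (0.45 log units; beyond the scatter)) concerns a different change and shows only how far the numbers spread in this small set. Among the compounds with values here, no measurement yet covers a fluoro at the new carbon, so the earlier gain may carry over only in part.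

The expected change is small and toward stronger inhibition, estimated as a 1.6-fold lower number from compound 3 to compound 4 (0.22 log units; within the scatter) in this assay. Compound 4 is expected near 4400 nM with an estimated range from 2500 nM to 7800 nM.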

Compound 4, concentration for 50% growth inhibition: 2450 nM
Compound 4: middle estimate off by 1.8-fold (0.25 log units), on the high side, and the stated range ends above it.
By their numbers in this assay, from the lowest: compounds 4, 1 and 2 (each within the scatter of the next); then compound 3.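

Measured in this assay, a fluoro on this carbon of the benzyl ring, para to a large group, gives a clear though modest step (a 3.0-fold lower number from compound 3 to compound 4 (0.47 log units; beyond the scatter)), so a lower number than that of compound 3 now comes with a fluoro on either of two carbons of this ring. Where the fluoro sits makes no readable difference between these two carbons (a 1.3-fold lower number from compound 2 to compound 4 (0.10 log units; within the scatter)), and the 4-fluorobenzyl amide cannot be told apart from the phenyl amide (a 1.0-fold lower number from compound 1 to compound 4 (0.02 log units; within the scatter)), which leaves compound 3 as the only one of the four that stands apart from the others. Nothing available explains why adding this fluoro to the benzyl ring goes with stronger inhibition of growth.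

Still open, going by these compounds, is whether chloro, methoxy or a carboxylic acid on this same carbon would behave as fluoro does, or whether the step belongs to fluoro alone. On these data alone, it is also open whether 4-fluorophenyl in place of the phenyl of compound 1 would bring a similar step, or whether the fluoro matters only on the benzyl group.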